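This account rests on a few compounds, and the source may have more. Where it says the series, first, only, none or still open, it means among the compounds named here.

In an ADME assay on microsomes (Homo sapiens) for metabolic stability (a lower number here means slower removal, a higher number faster removal of the compound), two compounds sharing one core have been measured so far. Compound 1 `Cc1cc(C(F)(F)F)c2cccc(OCc3c(Cl)ccc(S(=O)(=O)N4CCC[C@H]4C(=O)O)c3Cl)c2n1`, with a 2-carboxypyrrolidin-1-yl group on its sulfonyl sulfur, gives 8.33 mL/min/kg. Compound 2 `Cc1cc(C(F)(F)F)c2cccc(OCc3c(Cl)ccc(S(=O)(=O)N4CC[C@@H](N(C)C)C4)c3Cl)c2n1`, with 3-(dimethylamino)pyrrolidin-1-yl in that place, gives 167 mL/min/kg, the higher of the two numbers. Compound 3 `Cc1cc(C(F)(F)F)c2cccc(OCc3c(Cl)ccc(S(=O)(=O)N4CCCC4)c3Cl)c2n1` differs from compound 2 by one change: hydrogen in place of dimethylamino on a saturated ring carbon. Hydrogen takes the place of dimethylamino on a saturated ring carbon, leaving a plain pyrrolidin-1-yl on the sulfonyl sulfur.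

Going by the values given here, only one measured step bears on this change: a 20-fold higher number from compound 1 to compound 2 (1.30 log units; beyond the scatter). It is large and beyond the scatter, so what the pyrrolidine ring carries can matter a great deal here. However, that step swaps one group for another, and no measured pair shows the removal of dimethylamino alone. Compound 3 carries neither group, so a number between those of the two measured compounds seems likely, given the gap of a 20-fold higher number from compound 1 to compound 2 (1.30 log units; beyond the scatter). A downward step is expected, a 3.3-fold lower number from compound 2 to compound 3 (0.52 log units; beyond the scatter), though this estimate is uncertain. For compound 3 the estimated number is 50 mL/min/kg, with an expected range from 15 mL/min/kg to 150 mL/min/kg.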

Compound 3, clearance: 233 mL/min/kg
Estimate against measurement, compound 3: 4.7-fold (0.67 log units) below; measured number above the stated range.
By their numbers in this assay, from the lowest: compound 1; then compounds 2 and 3 (each within the scatter of the next).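

With this assay as the read-out, removing dimethylamino from the saturated ring carbon gives a 1.4-fold higher number from compound 2 to compound 3 (0.14 log units; within the scatter), so at this position, two ring bonds from the ring nitrogen, this group leaves no readable mark on the number. The comparison with the carboxy compound gives a 28-fold higher number from compound 1 to compound 3 (1.45 log units; beyond the scatter) and now isolates a single change, hydrogen in place of carboxy, which compound 2 could not do because it differs from compound 1 in both the group and its place on the ring; the large gap therefore tracks the presence of carboxy in compound 1, not the presence of dimethylamino in compound 2. Nothing measured here gives a reason for either step.

Going by these compounds, it remains open whether a carboxylic acid on the ring carbon that carries dimethylamino in compound 2 would bring the number down as far as the carboxy group of compound 1 does. A methyl ester or a primary amide in the place of that carboxy group would show whether the free acid itself is needed, or whether other groups at that ring carbon give a similar number.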